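Replacing one group on a shared core

The compounds below may be only part of what the source reports. "The series", "measured", "known", "first", "only" and "open" are said of these compounds alone.

Measured so far:
Compound 1, `COc1cc(OC)c2c(=O)cc(/C=C/c3ccc([N+](=O)[O-])cc3)oc2c1`: in a functional assay on HeLa cells (Homo sapiens) for antiproliferative activity, read by MTT assay, with a stated time of 12 h (a higher number here means a weaker inhibitor, a lower number a stronger inhibitor), compound 1 gives 9600 nM.
Compound 2, `COc1cc(OC)c2c(=O)cc(/C=C/c3ccc(OCC4CC4)cc3)oc2c1`: in this assay compound 2 gives 10900 nM.

Among the compounds with values here, compound 1 has the lowest number of the two measured, but its only neighbour, compound 2, sits so close that the step of a 1.1-fold higher number from compound 1 to compound 2 (0.06 log units; within the scatter) tells nothing about order; the two cannot be told apart.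

Compound 3, `COc1cc(OC)c2c(=O)cc(/C=C/c3ccc(C(F)(F)F)cc3)oc2c1`, is reached from compound 1 by one change: trifluoromethyl in place of nitro on an aromatic carbon. Within the data shown here, the one measured step that bears on this change is the one from compound 1 to compound 2, where the same nitro was swapped for another group on the same aromatic carbon and the number barely moved. On that basis, the step from compound 1 to compound 3 in this assay is expected to show no change beyond the scatter, that is a 1.0-fold higher number from compound 1 to compound 3 (0.02 log units; within the scatter). Compound 3 is therefore estimated at 10000 nM, in the range 4000 nM to 25000 nM.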

Compound 3, half-maximal inhibitory concentration: 19000 nM
The estimate for compound 3 lay 1.9-fold (0.28 log units) below the measured number, and the stated range covers the measured number.
By their numbers in this assay, from the lowest: compounds 1, 2 and 3 (each within the scatter of the next).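

With trifluoromethyl, a third group now sits on this aromatic carbon, para to a large group, and this assay still separates none of the three compounds: the result is a 2.0-fold higher number from compound 1 to compound 3 (0.30 log units; within the scatter), and alongside it a 1.7-fold higher number from compound 2 to compound 3 (0.24 log units; within the scatter). Nitro counts 2 hydrogen-bond acceptors and trifluoromethyl 0, so at this position, exchanging one for the other gives a step that stays within the scatter, which the single earlier step could not show. No measurement shown here offers an explanation for these numbers.

Still open, from the compounds shown here alone, is whether any group on this carbon can move the number beyond the scatter, for example an amine, a carboxylic acid or a longer chain. Plain hydrogen at this place would also show whether a substituent here matters at all.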